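Swapping a methyl for hydroxy on the chain of compound 3

The source may report more compounds than this note shows. Statements on the series, on what has been measured and on what is new or still open speak of the compounds shown alone.

Compound 1, `CN1CCN(C(=O)c2cc3c(Nc4ccc(OC(F)(F)F)cc4)ncnc3s2)CC1`, in an ADME assay on BaF3 cells (Mus musculus) for cytotoxicity (a lower number here means that less compound is needed, a higher number that more compound is needed for the effect), gives 2690 nM.
Compound 2, `Nc1cccc(-c2cc(Nc3ccc(OC(F)(F)F)cc3)ncn2)c1`, gives only the limit of this assay, > 10000 nM.
Compound 3, `CCCn1cc2c(Nc3ccc(OC(F)(F)F)cc3)ncnc2n1`, likewise gives only the limit, > 10000 nM.

Compound 3 therefore stands at the limit of > 10000 nM in this assay, at which 2 of the 3 values shown sit, so no number is known for it, only that it lies beyond the reach of this assay. Compound 4, `OCCn1cc2c(Nc3ccc(OC(F)(F)F)cc3)ncnc2n1`, differs from it in one place: hydroxy in place of methyl on a saturated chain carbon, two bonds along the chain from an aromatic nitrogen. Going by the values given here, with no measured pair showing what such a change does, the expected step from compound 3 to compound 4 is none beyond the scatter, and the expected result is again most likely a limit. The estimated step is a step that the limit leaves unreadable from compound 3 to compound 4. Compound 4 is expected at 15000 nM, with a range from 5000 nM to 50000 nM.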

Compound 4, half-maximal effective concentration: > 10000 nM
Compound 4: a limit, no number (the forecaster's own chance of this, stated with the estimate: 80%); the middle value does not contradict the limit.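

Compound 3 and compound 4 each give only a limit, not a number, so no step between them can be read: the limit of > 10000 nM in this assay, at which 3 of the 4 values shown sit.

From the compounds shown here alone, whether hydroxy in place of methyl on this chain changes the result in this assay stays open.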